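A few compounds are considered here, and "the series" means these few. Any claim that something is new, unique, unknown or untested is made for them only; others in the source may bear on it.

Compound 1 `CC/C(=C(/c1ccc(NC(=O)C(C)C)cc1)c1ccc(OC)cc1)c1ccccc1`: > 30000 nM (a limit)
Compound 2 `CC/C(=C(\c1ccccc1)c1ccc(NC(=O)C(C)C)cc1)c1ccc(Cl)cc1Cl`: 3300 nM

Among the measured compounds shown here, in a functional assay on HeLa cells (Homo sapiens) for inhibition, read by trypan blue exclusion, with a stated time of 72 h (on this read-out higher numbers stand for weaker inhibition of growth and lower numbers for stronger inhibition of growth), compound 2 gives 3300 nM, the only actual number so far. Compound 3 `CC/C(=C(/c1ccc(NC(=O)C(C)C)cc1)c1ccc(OC)cc1)c1ccc(Cl)cc1Cl` departs from compound 2 by one change, methoxy in place of hydrogen on an aromatic carbon, turning phenyl to 4-methoxyphenyl: methoxy in place of hydrogen on an aromatic carbon. For the measured compounds named here, no measured pair isolates this change. Compound 1 also carries the 4-methoxyphenyl and stands only at the limit > 30000 nM, so weaker inhibition of growth, beyond the scatter, is expected. The expected size is a 2.1-fold higher number from compound 2 to compound 3 (0.33 log units; beyond the scatter). For compound 3 the estimated value is 7000 nM, with an expected range of 2500 nM to 25000 nM.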

Compound 3, concentration for 50% growth inhibition: 2200 nM
Compound 3: the middle estimate sits 3.2-fold (0.50 log units) above what was measured; measured number outside the range, below it.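

In this assay, methoxy on this aromatic carbon, para to a large group, shows no effect beyond the scatter when the 2,4-dichlorophenyl is present: the change gives a 1.5-fold lower number from compound 2 to compound 3 (0.18 log units; within the scatter). With the 4-methoxyphenyl held constant, the 2,4-dichlorophenyl in place of phenyl gives an at least 13-fold lower number from compound 1 to compound 3 (1.13 log units; beyond the scatter). Compound 1 stands at a limit, so this step is a bound rather than an exact size: the limit of > 30000 nM in this assay, at which 1 of the 3 values shown sits.

From the compounds shown here alone, whether a hydroxyl, an amine or a longer alkoxy chain on the same carbon would match methoxy remains open. So does whether methoxy would be equally neutral with phenyl in place of the 2,4-dichlorophenyl.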